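A methoxy step from compound 1 to compound 4

The source may report more compounds than this note shows. Statements on the series, on what has been measured and on what is new or still open speak of the compounds shown alone.

Values measured so far in an ADME assay for permeability, using PAMPA, at pH 7.4 (a lower number here means that the compound crosses the layer more slowly, a higher number that the compound crosses the layer faster), are shown here:
Compound 1 `Cc1[nH]c2ccccc2c(=O)c1Cc1ccccc1` gives 102 10^-6 cm/s
Compound 2 `Cc1[nH]c2ccccc2c(=O)c1/C=C/c1cccc([N+](=O)[O-])c1` gives 602 10^-6 cm/s
Compound 3 `Cc1ccc2[nH]c(C)c(Br)c(=O)c2c1` gives 42.2 10^-6 cm/s

Compound 1 stands second highest of the three, with compound 3 lower and compound 2 higher, both gaps beyond the scatter. Compound 4 `COc1ccc2[nH]c(C)c(Cc3ccccc3)c(=O)c2c1` has not been measured. It differs from compound 1 in one place (methoxy in place of hydrogen on an aromatic carbon), with methoxy in place of hydrogen on an aromatic carbon. Going by the values given here, no measured pair shows this change, so the direction is unknown. The expected 1.1-fold lower number from compound 1 to compound 4 (0.03 log units; within the scatter) is small and stays within the scatter. Starting from compound 1 at 102 10^-6 cm/s as the only guide, compound 4 is estimated at 95 10^-6 cm/s with an expected range from 40 10^-6 cm/s to 230 10^-6 cm/s in this estimate.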

Compound 4, apparent permeability: 188 10^-6 cm/s
Estimate against measurement, compound 4: 2.0-fold (0.30 log units) below; the measured number falls inside the stated range.
By their numbers in this assay, from the lowest: compound 3; then compounds 1 and 4 (each within the scatter of the next); then compound 2.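

Going by these compounds alone, this is the first pair in this assay that differs in one place: swapping hydrogen for methoxy on this aromatic carbon gives a 1.8-fold higher number from compound 1 to compound 4 (0.27 log units; within the scatter), a step that repeat measurements alone could produce. At this position, then, methoxy leaves the number indistinguishable from that of compound 1. Nothing available bears on what lies behind the step. Still open, going by these compounds, is whether an amine or a longer chain such as ethoxy at the same carbon would move the number beyond the scatter. On these data alone, whether methoxy would behave alike on another carbon of that ring also remains open.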